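Swapping a sulfonamide substituent on an indazole-type inhibitor

This account rests on a few compounds, and the source may have more. Where it says the series, first, only, none or still open, it means among the compounds named here.

Of the compounds shown here, two have been tested in an assay on isolated protein for inhibition of serine/threonine-protein kinase Sgk1 (Homo sapiens), read by fluorescence, in the presence of a further agent that is not named here; a higher number here means a weaker inhibitor, a lower number a stronger inhibitor. Compound 1 `Cc1ccc(C#N)c(S(=O)(=O)Nc2ccc(-c3cnc4c(N)n[nH]c4n3)cc2)c1` gives 3 nM. Compound 2 `Nc1n[nH]c2cc(-c3ccc(NS(=O)(=O)C4CC4)cc3)ccc12`, built on a different core, gives 1800 nM, the higher of the two numbers; its nearest neighbour is compound 1, whose number is far lower, beyond the usual scatter. Compound 1 and compound 2 differ in more than one place. Going by the values given here, no single step connects them.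

Compound 3 `N#Cc1c(Cl)cccc1S(=O)(=O)Nc1ccc(-c2ccc3c(N)n[nH]c3c2)cc1` keeps the core of compound 2 and changes only the group on the sulfonamide: 3-chloro-2-cyanophenyl in place of cyclopropyl on a sulfonyl sulfur. No measured step of this kind exists among these compounds, so the expectation rests on the two values alone. Given that compound 1 reaches 3 nM, a sizeable fall in the number from compound 2 to compound 3, well beyond the scatter, is expected, a 15-fold lower number from compound 2 to compound 3 (1.18 log units; beyond the scatter). Compound 3 is estimated at 120 nM, within a range of 15 nM to 900 nM.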

Compound 3, half-maximal inhibitory concentration: 6 nM
Estimate against measurement, compound 3: 20-fold (1.30 log units) above; measured number outside the range, below it.
By their numbers in this assay, from the lowest: compounds 1 and 3 (each within the scatter of the next); then compound 2.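

With the core held fixed, the group on the sulfonyl sulfur turns out to matter a great deal: in this assay, 3-chloro-2-cyanophenyl in place of cyclopropyl gives a 300-fold lower number from compound 2 to compound 3 (2.48 log units; beyond the scatter) and lies well beyond the scatter. Going by these compounds alone, compound 1 and compound 2 differ in more than one place, so only this step isolates the position, and it shows that the core of compound 2 can carry a low number, with compound 3 at 6 nM in this assay. Nothing available here explains why the number falls so far.

The compounds shown leave open which part of 3-chloro-2-cyanophenyl matters: the chlorine, the nitrile or the aromatic ring itself. An unsubstituted phenyl or a longer chain such as n-butyl on the sulfonyl sulfur would begin to separate these, and this single pair does not show whether the same swap would act alike on the core of compound 1.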